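The source may report more compounds than this note shows. Statements on the series, on what has been measured and on what is new or still open speak of the compounds shown alone.

In a functional assay on SiHa cells (Homo sapiens) for inhibition (a higher number here means a weaker inhibitor, a lower number a stronger inhibitor), compound 1 (`COc1cc(/C=C/C(=O)c2cccc(NC(=O)c3ccc(Cl)cc3Cl)c2)ccc1O`) gives 34.4 ug/mL and compound 2 (`COc1cc(/C=C/C(=O)c2cccc(NC(=O)c3ccc(Cl)c(Cl)c3)c2)ccc1O`) gives 25.3 ug/mL. Among the compounds with values here, compound 2 therefore stands level with compound 1, the only other measured member of the series. Compound 3 (`COc1cc(/C=C/C(=O)c2cccc(NC(=O)c3ccccc3)c2)ccc1O`) is the next to be read, and the change is phenyl in place of 3,4-dichlorophenyl on a carbonyl carbon. Within the data shown here, the only measured step that bears on this is a 1.4-fold lower number from compound 1 to compound 2 (0.13 log units; within the scatter), an exchange of one dichlorophenyl for another, and on that basis no step beyond the scatter is expected in this assay, in either direction. Among the measured compounds shown here, no measured compound lacks the chlorine atoms, so this expectation is weakly supported and the range is kept wide. The estimate amounts to a 1.2-fold higher number from compound 2 to compound 3 (0.07 log units; within the scatter). For compound 3 the expected value is 30 ug/mL, with an estimated range of 13 ug/mL to 65 ug/mL.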

Compound 3, half-maximal inhibitory concentration: 4.57 ug/mL
Estimate against measurement, compound 3: 6.6-fold (0.82 log units) above; the whole stated range lies above it.
By their numbers in this assay, from the lowest: compound 3; then compounds 2 and 1 (each within the scatter of the next).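

In this assay, this position on the carbonyl carbon proves sensitive to the loss of the chlorine atoms, which the exchange of one dichlorophenyl for the other did not show: phenyl in place of 3,4-dichlorophenyl gives a 5.5-fold lower number from compound 2 to compound 3 (0.74 log units; beyond the scatter) and phenyl in place of 2,4-dichlorophenyl gives a 7.5-fold lower number from compound 1 to compound 3 (0.88 log units; beyond the scatter) in the same assay. Among these compounds, the benzoyl compound 3 therefore stands apart from both dichlorinated compounds, and neither of them goes against this. No measured information accounts for this difference.

As far as these compounds go, whether a single chlorine, a methyl or a methoxy group on the phenyl ring reads with compound 3 or with the dichlorinated pair stays open. Also open, from the compounds shown here alone, is whether the same exchange gives a similar step when the remainder of the shared core is changed.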